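This account rests on a few compounds, and the source may have more. Where it says the series, first, only, none or still open, it means among the compounds named here.

Within the data shown here, the three compounds measured so far share one core and differ in the groups hung from it. Compound 1, `CC(c1ccc(-c2ccccc2)c(F)c1)c1nnc2n1N=C(c1ccc(Cl)cc1)CS2`, gives in a functional assay on Huh-7 cells (Homo sapiens) for inhibition, read by sulforhodamine B assay, with a stated time of 72 h (on this read-out higher numbers stand for weaker inhibition and lower numbers for stronger inhibition), a value of 3900 nM. Compound 2, `COc1ccc2cc(C(C)c3nnc4n3N=C(c3ccc(Cl)cc3Cl)CS4)ccc2c1`, gives in this assay a value of 10700 nM. Compound 3, `CC(C)Cc1ccc(C(C)c2nnc3n2N=C(c2ccc(C(F)(F)F)cc2)CS3)cc1`, gives in this assay a value of 8400 nM. Among these three numbers, compound 2 stands highest; its gap to compound 3 falls within the usual scatter, so those two cannot be told apart, while its gap to compound 1 lies beyond the scatter.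

Compound 4, `COc1ccc2cc(C(C)c3nnc4n3N=C(c3ccc(OC(F)(F)F)cc3)CS4)ccc2c1`, has not yet been measured. It differs from compound 2 in one place: 4-(trifluoromethoxy)phenyl in place of 2,4-dichlorophenyl on a carbon with a double bond to nitrogen. Among the measured compounds shown here, no pair of measured compounds differs in exactly one place, so no single step has been seen that would show what such a swap does. The closest hint is that compound 3 carries a related group at the same place and sits near compound 2. A small step is therefore expected from compound 2 to compound 4, a 1.5-fold lower number from compound 2 to compound 4 (0.18 log units; within the scatter), leaning toward a lower number but not clearly beyond the scatter. For compound 4 the expected value in this assay is 7000 nM, with a likely range from 2500 nM to 20000 nM.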

Compound 4, half-maximal inhibitory concentration: 16000 nM
Compound 4: middle estimate off by 2.3-fold (0.36 log units), on the low side; the measured number falls inside the stated range.
By their numbers in this assay, from the lowest: compound 1; then compounds 3, 2 and 4 (each within the scatter of the next).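

Among these compounds, this is the first direct reading of a change at this position, the carbon with a double bond to nitrogen, with the rest of the molecule held fixed. In this assay, putting 4-(trifluoromethoxy)phenyl in place of 2,4-dichlorophenyl gives a 1.5-fold higher number from compound 2 to compound 4 (0.17 log units; within the scatter), so compound 2 and compound 4 cannot be told apart, even though the entering group has 11 heavy atoms against 8, carries a hydrogen-bond acceptor and has no chlorine. Nothing shown here offers a reason for this outcome.

This single pair, taken on one background, cannot say whether the same swap would also leave the number unresolved alongside the other groups carried by compound 1 and compound 3, whose cores differ from these in more than one place. It also leaves open what happens at this position when the phenyl ring bears an amine or a carboxylic acid, or when a longer alkyl chain replaces the ring altogether.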